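This account rests on a few compounds, and the source may have more. Where it says the series, first, only, none or still open, it means among the compounds named here.

Working notes on the series. Among the compounds with values here, in a functional assay on MKN-45 cells (Homo sapiens) for cytotoxicity, read by MTT assay, with a stated time of 72 h (a higher number here means a weaker inhibitor, a lower number a stronger inhibitor), compound 3 `CN(C)CCn1cnnc1-c1cc(Oc2ccc(NC(=O)N/N=C/c3c(O)ccc4ccccc34)cc2F)ccn1` gives 2020 nM and stands second highest of the three numbers so far. Compound 1 `COc1ccc(OC)c(/C=N/NC(=O)Nc2ccc(Oc3ccnc(-c4nncn4CCN(C)C)c3)c(F)c2)c1` is nearest with 1510 nM, and compound 2 `CN(C)CCn1cnnc1-c1cc(Oc2ccc(NC(=O)N/N=C/c3cc(Br)c(O)c(Br)c3)cc2F)ccn1` is furthest with 4320 nM. Compound 4 `CN(C)CCn1cnnc1-c1cc(Oc2ccc(NC(=O)N/N=C/c3ccc(F)cc3)cc2F)ccn1` is not yet measured. The change from compound 3 is 4-fluorophenyl in place of 2-hydroxynaphthalen-1-yl on a carbon with a double bond to nitrogen. All three known steps alter the same group on the carbon with a double bond to nitrogen: a 2.9-fold higher number from compound 1 to compound 2 (0.46 log units; beyond the scatter), a 1.3-fold higher number from compound 1 to compound 3 (0.13 log units; within the scatter) and a 2.1-fold lower number from compound 2 to compound 3 (0.33 log units; beyond the scatter). Those steps were modest or within the scatter, so only a small step in this assay is expected here, in either direction. Compound 4 is therefore estimated at 2000 nM, with a range from 800 nM to 5000 nM. The expected step is a 1.0-fold lower number from compound 3 to compound 4 (0.00 log units; within the scatter).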

Compound 4, half-maximal inhibitory concentration: 1030 nM
Beside the measured number, compound 4's estimate is 1.9-fold (0.29 log units) above it; measured number inside the range.
By their numbers in this assay, from the lowest: compounds 4, 1 and 3 (each within the scatter of the next); then compound 2.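

In this assay, 4-fluorophenyl on the carbon with a double bond to nitrogen, with 0 hydrogen-bond donors and 0 hydrogen-bond acceptors, shows no separation from the larger 2-hydroxynaphthalen-1-yl: a 2.0-fold lower number from compound 3 to compound 4 (0.29 log units; within the scatter). The same holds against 2,5-dimethoxyphenyl: a 1.5-fold lower number from compound 1 to compound 4 (0.17 log units; within the scatter). Only 3,5-dibromo-4-hydroxyphenyl stands apart, with a 4.2-fold lower number from compound 2 to compound 4 (0.62 log units; beyond the scatter).

No measurement on hand accounts for these steps. On these data alone, whether a plain phenyl, or a phenyl carrying an amine or a carboxylic acid, would stay level with compound 4 remains open.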